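A few compounds are considered here, and "the series" means these few. Any claim that something is new, unique, unknown or untested is made for them only; others in the source may bear on it.

Among the measured compounds shown here, in an ADME assay (liver) for metabolic stability, with Liver microsome (Rattus norvegicus) as the target, using microsomes and NADPH, with a stated time of 30 min, tested at 1 uM (on this read-out higher numbers stand for fast clearance and lower numbers for slow clearance), compound 1 `Nc1ccc(S(=O)(=O)N2CCN(c3ncc(C(O)(C(F)(F)F)C(F)(F)F)cc3C3CC3)CC2)cn1` gives 27 mL.min-1.g-1, while compound 2 `Nc1ccc(S(=O)(=O)N2CCN(c3ncc(C(O)(C(F)(F)F)C(F)(F)F)cc3-c3ccccc3O)CC2)cn1` gives 125 mL.min-1.g-1, the higher of the two numbers so far. Next in the series is compound 3 `CS(=O)(=O)Nc1cccc(-c2cc(C(O)(C(F)(F)F)C(F)(F)F)cnc2N2CCN(S(=O)(=O)c3ccc(N)nc3)CC2)c1`, not yet measured. The change is 3-(methanesulfonamido)phenyl in place of 2-hydroxyphenyl on an aromatic carbon: 3-(methanesulfonamido)phenyl in place of 2-hydroxyphenyl, at the place ortho to a large group. For the measured compounds named here, one measured step bears on it: a 4.6-fold higher number from compound 1 to compound 2 (0.67 log units; beyond the scatter), with 2-hydroxyphenyl in place of cyclopropyl at the same place. Going by the values given here, that step starts from a different group, and no measured step compares two substituted phenyl groups, so it is only a weak guide. Both groups keep a six-membered aromatic ring of carbon only, so no change beyond the scatter is expected in this assay. The estimated step is a 1.4-fold lower number from compound 2 to compound 3 (0.14 log units; within the scatter). For compound 3 the expected value is 90 mL.min-1.g-1, with an estimated range of 35 mL.min-1.g-1 to 220 mL.min-1.g-1.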

Compound 3, intrinsic clearance in microsomes: 81 mL.min-1.g-1
Compound 3: middle estimate off by 1.1-fold (0.05 log units), on the high side, within the range that was stated.
By their numbers in this assay, from the lowest: compound 1; then compounds 3 and 2 (each within the scatter of the next).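

In this assay, a second substituted phenyl group at this place, ortho to a large group, stays close to the first: a 1.5-fold lower number from compound 2 to compound 3 (0.19 log units; within the scatter), with 3-(methanesulfonamido)phenyl in place of 2-hydroxyphenyl. The separation from cyclopropyl now holds for a second aryl group, a 3.0-fold higher number from compound 1 to compound 3 (0.48 log units; beyond the scatter), and among these three compounds the higher clearance numbers both belong to the substituted phenyl groups, with no compound going against this. No measurement bears on what lies behind these differences.

The substituent and its location on the phenyl ring differ together between compound 2 and compound 3, so the contribution of each remains unresolved. Also open, from the compounds shown here alone, is whether a phenyl group carrying a carboxylic acid or an amine, or a longer alkyl chain in place of the ring, would fall nearer compound 1 or nearer compound 3.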